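From isobutyl to 4-bromophenyl on the aromatic nitrogen

The source may hold more compounds than are shown below. What is called first, only, known or untested is meant among the compounds shown, and "the series" means these compounds.

Compound 1 (`COc1cc(-c2nccn2CC(C)C)cc(OC)c1OC`) was tested in a functional assay on T47D cells (Homo sapiens) for antiproliferative activity, read by MTT assay, with a stated time of 72 h (a higher number here means a weaker inhibitor, a lower number a stronger inhibitor), and returned only a limit, not a number (> 100000 nM). Compound 1 sits at the limit of > 100000 nM in this assay, at which 1 of the 2 values shown sits, and so offers no exact starting point for a step.

Compound 2 (`COc1ccc(-n2ccnc2-c2cc(OC)c(OC)c(OC)c2)cc1[N+](=O)[O-]`) gives a true number in this assay of 10000 nM and is the only such figure so far.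

Compound 3 (`COc1cc(-c2nccn2-c2ccc(Br)cc2)cc(OC)c1OC`) has not been measured. It differs from compound 1 in one place (4-bromophenyl in place of isobutyl on an aromatic nitrogen), with 4-bromophenyl in place of isobutyl on an aromatic nitrogen. Going by the values given here, no measured step sizes this change, so the expectation leans on compound 2 at 10000 nM as the nearest measured guide. The step expected in this assay is an at least 12-fold lower number from compound 1 to compound 3 (1.09 log units; beyond the scatter) and runs toward a stronger inhibitor, though this size is only an estimate and the starting point is a limit. For compound 3 the estimated value is 8000 nM with an expected range from 800 nM to 60000 nM in this assay as a rough working figure.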

Compound 3, half-maximal inhibitory concentration: 24600 nM
The estimate for compound 3 lay 3.1-fold (0.49 log units) below the measured number; measured number inside the range.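

In this assay, 4-bromophenyl in place of isobutyl on the aromatic nitrogen gives an at least 4.0-fold lower number from compound 1 to compound 3 (0.60 log units; beyond the scatter), the first step sized at this position. That size is only a floor, since the starting point for compound 1 is a limit and not a number: the limit of > 100000 nM in this assay, at which 1 of the 3 values shown sits.

Compound 2 also carries an aromatic ring on that nitrogen and gives 10000 nM, while compound 3 gives 24600 nM, so both compounds with an aromatic ring there return true numbers in this assay.

On these data alone, it remains open whether the step belongs to the aromatic ring or to the bromine, a question that plain phenyl, 4-chlorophenyl or 4-fluorophenyl on the same nitrogen would separate. As far as these compounds go, it is equally open whether an aromatic ring is needed at all, which a cyclohexyl group, a benzyl group or a longer chain carrying an amine at this position would help to settle.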